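Cyclopropyl alkyne active, aryl alkynes at the limit

A few compounds are considered here, and "the series" means these few. Any claim that something is new, unique, unknown or untested is made for them only; others in the source may bear on it.

Measured in a functional assay on HL-60 cells (Homo sapiens) for antiproliferative activity, with a stated time of 72 h (on this read-out higher numbers stand for weaker inhibition and lower numbers for stronger inhibition), so far:
- compound 1 `Nc1ncnn2c([C@@H]3O[C@H](CO)[C@@H](O)[C@H]3O)cc(C#CC3CC3)c12` gives 40 nM as a number
- compound 2 `Nc1ncnn2c([C@@H]3O[C@H](CO)[C@@H](O)[C@H]3O)cc(C#Cc3ccc(F)cc3)c12` gives > 100000 nM as a limit
- compound 3 `Nc1ncnn2c([C@@H]3O[C@H](CO)[C@@H](O)[C@H]3O)cc(C#Cc3ccccc3)c12` gives > 100000 nM as a limit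

Compound 3 sits on the limit of > 100000 nM in this assay, at which 2 of the 3 values shown sit, and so has a limit and no number. Compound 4 `COc1ccc(-c2cc([C@@H]3O[C@H](CO)[C@@H](O)[C@H]3O)n3ncnc(N)c23)cc1` differs from it by 4-methoxyphenyl in place of 2-phenylethynyl on an aromatic carbon and so carries 4-methoxyphenyl in place of 2-phenylethynyl on an aromatic carbon, with the triple bond gone.

Among the measured compounds shown here, two measured steps bear on this change. Phenyl in place of cyclopropyl gave an at least 2500-fold higher number from compound 1 to compound 3 (3.39 log units; beyond the scatter) and 4-fluorophenyl in the same place gave an at least 2500-fold higher number from compound 1 to compound 2 (3.39 log units; beyond the scatter) and both steps are large. Hydrogen in place of fluoro gave a step that the two limits leave unreadable from compound 2 to compound 3 and adds nothing further.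

Compound 4 keeps the six-membered aromatic ring of carbon only that came with both large steps, as seen in an at least 2500-fold higher number from compound 1 to compound 3 (3.39 log units; beyond the scatter) and so it is expected to stay weak. Every measured compound has the triple bond, so a small move toward a lower number remains possible. The expected step is an at least 2.0-fold lower number from compound 3 to compound 4 (0.30 log units; that floor lies within the scatter) and it is only an estimate set against a limit. For compound 4 the estimated value is 50000 nM with an expected range from 5000 nM to 100000 nM in this assay and a report of only a limit is likely.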

Compound 4, half-maximal inhibitory concentration: > 100000 nM
Compound 4: a limit, no number (the forecaster's own chance of this, stated with the estimate: 60%); middle value at least 2.0-fold (0.30 log units) from the limit.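

In this assay compound 4 gives > 100000 nM, which is a limit and not a number. Until now every compound at this position carried the triple bond, and compound 4 shows that the six-membered aromatic ring of carbon only goes with the loss even with the triple bond gone, at an at least 2500-fold higher number from compound 1 to compound 4 (3.39 log units; beyond the scatter), leaving compound 1, with its 2-cyclopropylethynyl group, as the one compound against the pattern among those shown. The steps among compound 2, compound 3 and compound 4 cannot be read, and the aryl groups at this place cannot be ranked, as all three compounds sit at the same ceiling: the limit of > 100000 nM in this assay, at which 3 of the 4 values shown sit.

With a number for compound 1 alone, the compounds shown leave open whether the triple bond itself contributes anything, which a cyclopropyl group set directly on the aromatic carbon would address. They also leave open how much room the alkyne carries beyond cyclopropyl, for instance with a cyclobutyl group, a longer alkyl chain or a terminal amine in its place.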